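This account rests on a few compounds, and the source may have more. Where it says the series, first, only, none or still open, it means among the compounds named here.

Measured compounds:
- compound 1 `COc1ccc(OCC(=O)N2CCC3(CC2)CN(Cc2ccc(OCC(C)C)cc2Cl)C3)cc1`: 86 nM
- compound 2 `COc1ccc(OCC(=O)N2CCC3(CC2)CN(Cc2ccc(-c4nnc(C)o4)cc2)C3)cc1`: 1070 nM
- compound 3 `COc1ccc(OCC(=O)N2CCC3(CC2)CN(Cc2ccc(-n4nccn4)cc2Cl)C3)cc1`: 14 nM

All three were run in an assay on HEK293 cells for displacement of a labelled ligand from growth hormone secretagogue receptor type 1 (Homo sapiens), with a stated time of 8 h; on this read-out higher numbers stand for weaker inhibition and lower numbers for stronger inhibition. Among the three numbers, compound 1 stands second highest: compound 3 lies at a 6.1-fold lower number from compound 1 to compound 3 (0.79 log units; beyond the scatter), while compound 2, which differs from compound 1 in more than one place, sits at the high end. Compound 1 gives 86 nM, and compound 2 gives 1070 nM.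

Compound 4 `COc1ccc(OCC(=O)N2CCC3(CC2)CN(Cc2ccc(OCC(C)C)cc2Cl)C3)cn1` has not been measured. It differs from compound 1 by 6-methoxypyridin-3-yl in place of 4-methoxyphenyl on an oxygen on a saturated carbon. Going by the values given here, this change sits on the ether-linked aryl group, not on the aromatic ring where compound 1 carries isobutoxy and where the only single-point step, a 6.1-fold lower number from compound 1 to compound 3 (0.79 log units; beyond the scatter), was recorded. Among the compounds with values here, that step therefore offers no direct precedent for the change to compound 4, and compound 2 gives none either, since it differs in several places at once. Within the data shown here, with no measured step on this part of the shared core, the expectation for this assay is a step of no more than the usual scatter, in either direction: the estimated step is a 1.4-fold higher number from compound 1 to compound 4 (0.14 log units; within the scatter). For compound 4 the expected value in this assay is 120 nM, with a range of 40 nM to 400 nM.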

Compound 4, half-maximal inhibitory concentration: 59 nM
Beside the measured number, compound 4's estimate is 2.0-fold (0.31 log units) above it; the measured number falls inside the stated range.
By their numbers in this assay, from the lowest: compound 3; then compounds 4 and 1 (each within the scatter of the next); then compound 2.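

In this assay, 6-methoxypyridin-3-yl in place of 4-methoxyphenyl on an oxygen on a saturated carbon gives a 1.5-fold lower number from compound 1 to compound 4 (0.16 log units; within the scatter), so the two compounds cannot be told apart on this read-out. Going by these compounds alone, this is the first single-place step on this part of the series, and it shows that, with isobutoxy held constant, the ring nitrogen can enter this aryl group without a step beyond the scatter, whereas the only earlier single-place step, a 6.1-fold lower number from compound 1 to compound 3 (0.79 log units; beyond the scatter), concerned a different aromatic ring. No measurement shown here gives a reason for this result or says what the ring nitrogen does in the assay.

Still open, as far as these compounds go, is whether the 6-methoxypyridin-3-yl group would give a similar result alongside the 2H-1,2,3-triazol-2-yl group of compound 3, since a single step on the isobutoxy compound cannot settle that. Also open, from the compounds shown here alone, is how far this position tolerates larger departures, such as a pyrimidine ring in place of the pyridine, or an amine or a carboxylic acid in place of the methoxy group.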